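Swapping a Fluoro for a Methoxyethoxy Tail

The compounds below may be only part of what the source reports. "The series", "measured", "known", "first", "only" and "open" are said of these compounds alone.

Compound 1 `Fc1ccc(-c2nn3c(NC4CCCC4)nccc3c2-c2ccnc(NC3CCCC3)n2)cc1` was tested in an ADME assay on Vero cells (Chlorocebus sabaeus) for cytotoxicity; a lower number here means that less compound is tolerated, a higher number that more compound is tolerated. In this assay compound 1 gives > 40000 nM, which is a limit of the assay rather than a number. Compound 2 `Fc1ccc(-c2nn3c(N4CCCCC4)nccc3c2-c2ccnc(NC3CCCC3)n2)cc1` carries piperidin-1-yl in place of cyclopentylamino on an aromatic carbon; in this assay compound 2 gives > 40000 nM, again a limit. The step that the two limits leave unreadable from compound 1 to compound 2 is unreadable, as the limit of > 40000 nM in this assay, at which 2 of the 2 values shown sit, shows. Compound 3 `COCCOc1ccc(-c2nn3c(NC4CCCC4)nccc3c2-c2ccnc(NC3CCCC3)n2)cc1` differs from compound 1 by 2-methoxyethoxy in place of fluoro on an aromatic carbon. Among the compounds with values here, no measured step bears on this change, so no step beyond the scatter is assumed. Compound 3 is expected at 40000 nM (range 15000 nM to 100000 nM), an expected step of a number no higher from compound 1 to compound 3 (the limit leaves the size open).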

Compound 3, half-maximal cytotoxic concentration: > 40000 nM
Compound 3 was reported as a limit (the forecaster's own chance of this, stated with the estimate: 70%); the middle value lies on the limit itself.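

Within the data shown here, compound 3 stops at the same assay limit as compound 1, and no step between these two compounds can be read. In this assay the compounds shown leave open the concentration at which any of them harms the cells.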